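This account rests on a few compounds, and the source may have more. Where it says the series, first, only, none or still open, it means among the compounds named here.

Working notes on the series.

Compound 1 `O=S(=O)(Nc1ccc2oc(-c3ccccc3)nc2c1)c1ccc(Cl)c(Cl)c1` is the starting point. In an assay on cells for inhibition of HSP60/HSP10 (Homo sapiens), with a stated time of 60 min (on this read-out lower numbers stand for stronger inhibition and higher numbers for weaker inhibition), compound 1 gives only a limit of the assay, > 100000 nM, so its standing cannot be placed more exactly than that; it sits at the limit of > 100000 nM in this assay, at which 1 of the 3 values shown sits. Compound 2 `Cc1ccccc1S(=O)(=O)Nc1ccc(-c2nc3ccccc3o2)cc1` gives 85000 nM in this assay. Compound 3 `O=[N+]([O-])c1cc(S(=O)(=O)Nc2ccc3oc(-c4ccccc4)nc3c2)ccc1Cl` gives 17000 nM in this assay.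

For the measured compounds named here, one measured step bears on what a change on the sulfonyl side can do: an at least 5.8-fold lower number from compound 1 to compound 3 (0.76 log units; beyond the scatter), so a change on that ring has moved the number beyond the scatter in one case. Going by the values given here, the step to compound 4 `O=S(=O)(Nc1ccc2oc(-c3ccccc3)nc2c1)c1ccccc1F` is a different one, (2-fluorophenyl in place of 3,4-dichlorophenyl on a sulfonyl sulfur), and no measured pair shows this exchange, so the direction is open.

Given only the limit for compound 1 and no parallel step, compound 4 is expected to stay in the weak range, with a number no higher from compound 1 to compound 4 (the limit leaves the size open) as the expected step. The estimate for compound 4 in this assay is 100000 nM, with a range from 30000 nM to 300000 nM.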

Compound 4, half-maximal inhibitory concentration: > 100000 nM
Compound 4: a limit, no number; the forecaster's own chance of this, stated with the estimate: 50%; the middle value lies on the limit itself.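

In this assay compound 1 and compound 4 both stand only as limits, so no step between them can be read: the limit of > 100000 nM in this assay, at which 2 of the 4 values shown sit.

The compounds shown leave open how far 2-fluorophenyl in place of 3,4-dichlorophenyl on a sulfonyl sulfur moves the number, and in which direction.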